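Pyrrol-1-yl in place of dimethylamino on the pyridine-bearing alkyne

A few compounds are considered here, and "the series" means these few. Any claim that something is new, unique, unknown or untested is made for them only; others in the source may bear on it.

Going by the values given here, compound 2 `CN(C)c1ccc(C#Cc2c(F)cccc2F)cn1` stands highest of the two numbers so far: in a functional assay on LS174T cells (Homo sapiens) for inhibition, with a stated time of 4 days, tested at 1 uM (a higher number here means a stronger effect of the compound at the concentration tested, a lower number a weaker effect), compound 2 gives 77.9%, while compound 1 `Cc1ccc(C)n1-c1ccc(C#Cc2c(F)cccc2F)cc1` gives 20.9%, a gap beyond the scatter. Compound 3 `Fc1cccc(F)c1C#Cc1ccc(-n2cccc2)nc1` is not yet measured and differs from compound 2 by 1H-pyrrol-1-yl in place of dimethylamino on an aromatic carbon. Among the compounds with values here, no step between measured compounds covers this change, so the size of the step in this assay is open. A decrease is expected, since compound 1 at 20.9% also carries a 1H-pyrrol-1-yl. The estimate for compound 3 is 45%, between 15% and 75%. The expected step of a number 32.9 percentage points lower from compound 2 to compound 3 (beyond the scatter) lies beyond the scatter.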

Compound 3, a percentage reported as inhibition, at one concentration (the size of the read-out at that concentration, not a potency): 80.5%
Compound 3: the middle estimate sits 35.5 percentage points below what was measured; measured number outside the range, above it.
By their numbers in this assay, from the lowest: compound 1; then compounds 2 and 3 (each within the scatter of the next).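

In this assay, replacing dimethylamino with 1H-pyrrol-1-yl on the aromatic carbon next to the ring nitrogen gives a number 2.6 percentage points higher from compound 2 to compound 3 (within the scatter). This position therefore accepts a five-membered aromatic ring in place of an open dimethylamino group, with no readable difference at the concentration tested. Nothing measured here accounts for this result.

Still open, from the compounds shown here alone, is whether a saturated ring at this position, such as pyrrolidin-1-yl or morpholin-4-yl, holds the number in this assay. A primary amine or a methoxy group there is equally untested in the compounds shown.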